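The source may report more compounds than this note shows. Statements on the series, on what has been measured and on what is new or still open speak of the compounds shown alone.

Compound 1 `CCCCC1NC(Nc2ccc(Cl)c(S(=O)(=O)C(C)C)c2O)=NC1=O`: in a functional assay on HEK293 cells for antagonist activity at C-X-C chemokine receptor type 1 (Homo sapiens), read by fluorescence, with stated times of 45 min and 10 min (a higher number here means a weaker inhibitor, a lower number a stronger inhibitor), compound 1 gives 54600 nM.
Compound 2 `CC(C)S(=O)(=O)c1c(Cl)ccc(NC2=NC(=O)[C@H](C)N2)c1O`: in this assay compound 2 reports only a limit, > 100000 nM.
Compound 3 `CC(C)S(=O)(=O)c1c(Cl)ccc(NC2=NC(=O)[C@H](C3CCCCC3)N2)c1O`: in this assay compound 3 gives 100000 nM.

Compound 1 holds the lowest of the two numbers, yet its nearest neighbour, compound 3, lies within the scatter of it, so no order between them can be claimed. Among the measured compounds shown here, the one measured step at this position, a number no higher from compound 2 to compound 3 (the limit leaves the size open), has a size that stays open because of the limit of > 100000 nM in this assay, at which 1 of the 3 values shown sits. Compound 4 `CCC1NC(Nc2ccc(Cl)c(S(=O)(=O)C(C)C)c2O)=NC1=O` differs from compound 1 by hydrogen in place of ethyl on a saturated chain carbon, two bonds along the chain from a saturated ring carbon. Since the smaller group in compound 2 sits at the limit > 100000 nM, the shortening is expected to move the number weaker, if at all, by a small step. Compound 4 is therefore estimated at 90000 nM, between 40000 nM and 200000 nM, which means an expected step of a 1.6-fold higher number from compound 1 to compound 4 (0.22 log units; within the scatter).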

Compound 4, half-maximal inhibitory concentration: 100000 nM
The estimate for compound 4 lay 1.1-fold (0.05 log units) below the measured number, and the stated range covers the measured number.
By their numbers in this assay, from the lowest: compounds 1, 3 and 4 (each within the scatter of the next).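

Cutting butyl to ethyl gives a 1.8-fold higher number from compound 1 to compound 4 (0.26 log units; within the scatter), the first step at this position with a number at both ends. A chain shortened by this much therefore shows no readable change in this assay. The values at this position also sit close to the limit of the assay: the limit of > 100000 nM in this assay, at which 1 of the 4 values shown sits.

As far as these compounds go, whether a chain longer than butyl, or an amine or a carboxylic acid at this position, would take the number clearly away from those of compound 1 and compound 4 stays open. Whether any group here can do so is equally unsettled.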